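A few compounds are considered here, and "the series" means these few. Any claim that something is new, unique, unknown or untested is made for them only; others in the source may bear on it.

Measured so far in a functional assay on HOS cells (Homo sapiens) for antiproliferative activity, with a stated time of 72 h; a higher number here means a weaker inhibitor, a lower number a stronger inhibitor:

- compound 1 `Cc1ccc(CNc2ncnc3c2ncn3[C@@H]2O[C@H](CO)[C@@H](O)[C@H]2O)cc1`: > 166000 nM
- compound 2 `COc1cc(CNc2ncnc3c2ncn3[C@@H]2O[C@H](CO)[C@@H](O)[C@H]2O)cc(OC)c1`: "not determined" (no result reported)
- compound 3 `OC[C@H]1O[C@@H](n2cnc3c(NCc4c(F)ccc(F)c4F)ncnc32)[C@H](O)[C@@H]1O`: "not determined" (no result reported)

Compound 3 has no number to stand on, as its entry reads "not determined" (no result reported). Compound 2 is in the same position, with the entry "not determined" (no result reported). For compound 1 the entry > 166000 nM is a limit of the assay and not a number. Among the compounds with values here, the series therefore offers no measured potency, and no measured step between two compounds.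

The next compound is compound 4 `Cc1ccc(O)c(CNc2ncnc3c2ncn3[C@@H]2O[C@H](CO)[C@@H](O)[C@H]2O)c1`, which has not yet been measured. The change is 2-hydroxy-5-methylphenyl in place of 2,3,6-trifluorophenyl on a saturated chain carbon bound to a nitrogen on an aromatic ring.

Within the data shown here, with no step to size this change against, the only guide in this assay is compound 1 at > 166000 nM. Compound 4 is therefore expected to be a weak inhibitor, perhaps a modest step stronger than that limit, and it may itself return only a limit.

For compound 4 the estimated half-maximal inhibitory concentration is 60000 nM, with an expected range from 12000 nM to 166000 nM.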

Compound 4, half-maximal inhibitory concentration: > 166000 nM
Compound 4 gave a limit, no number; the forecaster's own chance of this, stated with the estimate: 45%; middle value at least 2.7-fold (0.44 log units) from the limit.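

In this assay compound 4 gives > 166000 nM as a limit of the assay and not a number. No step from compound 1 to compound 4 can be read, since both entries are limits: the limit of > 166000 nM in this assay, at which 2 of the 4 values shown sit.

Still open, from the compounds shown here alone, is whether any aromatic group on the shared core gives a measurable potency in this assay at all.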